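The source may report more compounds than this note shows. Statements on the series, on what has been measured and on what is new or still open speak of the compounds shown alone.

Working notes on the series.

Compound 1 `CCCCN(c1nc2c(NS(C)(=O)=O)cccc2o1)[C@H](C)c1ccc(-c2ccccc2-c2nnn[nH]2)cc1` carries a methanesulfonamido group on the shared core; in an ADME assay on the whole organism (plasma, Macaca fascicularis) for protein binding, read by LC-MS, using equilibrium dialysis and cassette dosing, with a stated time of 24 h, at a dose of 1 mg/kg by the oral route (a higher number here means a larger unbound share of the compound, a lower number a smaller unbound share), compound 1 gives 0.000203. Compound 2 `CCCCN(c1nc2c(-c3nccn3C)cccc2o1)[C@H](C)c1ccc(-c2ccccc2-c2nnn[nH]2)cc1` differs only at that position, and in this assay compound 2 gives 0.00299. Within the data shown here, the single step measured so far runs a 15-fold higher number from compound 1 to compound 2 (1.17 log units; beyond the scatter). Among the measured compounds shown here, on the two numbers known, compound 2 stands highest, and its distance to compound 1 is beyond the scatter.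

Compound 3 `CCCCN(c1nc2c(NC(C)=O)cccc2o1)[C@H](C)c1ccc(-c2ccccc2-c2nnn[nH]2)cc1` is the next variation at the same aromatic carbon: acetamido in place of 1-methyl-1H-imidazol-2-yl on an aromatic carbon. For the measured compounds named here, the only step that bears on this change is the one from compound 1 to compound 2, and it was large; it shows how strongly this position moves the read-out, but neither endpoint is an acetamido group, so the direction and size of the new step can only be bracketed. An acetamido group sits apart from both groups already measured, so the expected step of a 3.0-fold lower number from compound 2 to compound 3 (0.48 log units; beyond the scatter) in this assay is downward, but it is not expected to reach the size of the measured one. For compound 3 the estimated unbound fraction in this assay is 0.001, with a plausible range from 0.0003 to 0.003.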

Compound 3, unbound fraction: 0.00102
Compound 3: the middle estimate sits 1.0-fold (0.01 log units) below what was measured; the measured number falls inside the stated range.
By their numbers in this assay, from the lowest: compound 1; then compound 3; then compound 2.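

In this assay, the step of a 5.0-fold higher number from compound 1 to compound 3 (0.70 log units; beyond the scatter) isolates the group on the nitrogen: with that nitrogen kept on the aromatic carbon, acetyl in place of methylsulfonyl already moves the unbound fraction beyond the scatter, so the two nitrogen-linked groups do not behave alike at this position. The step of a 2.9-fold lower number from compound 2 to compound 3 (0.47 log units; beyond the scatter) shows that the acetamido group still falls short of 1-methyl-1H-imidazol-2-yl, which leaves compound 3 between the other two compounds and divides the large gap seen earlier into two modest steps. Nothing on hand gives a reason for either step.

From the compounds shown here alone, whether this order extends to a plain amine, a carboxylic acid or a longer acyl chain on the same aromatic carbon remains open, as three groups fix no trend. Going by these compounds, it is also open whether the higher number of compound 2 depends on the methyl group of its imidazole, which an unsubstituted imidazole or a different five-membered aromatic ring at this position would test.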